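Swapping octylamino for hydroxy on a carbonyl carbon

The source may report more compounds than this note shows. Statements on the series, on what has been measured and on what is new or still open speak of the compounds shown alone.

Compound 1 `CCC(NC(=O)C(CC(C)C)NC(=O)OCc1ccccc1)C(=O)C(=O)OC` gives 280000 nM in the first test
Compound 2 `CCCCCCCCNC(=O)C(=O)C(CC)NC(=O)C(CC(C)C)NC(=O)OCc1ccccc1` gives 200000 nM in the same test

Going by the values given here, in a functional assay for inhibition, with Rattus norvegicus as the target, at pH 7.35 (on this read-out higher numbers stand for weaker inhibition and lower numbers for stronger inhibition), compound 2 stands level with compound 1, with a 1.4-fold lower number from compound 1 to compound 2 (0.15 log units; within the scatter) as the only measured step. That step put octylamino in place of methoxy on a carbonyl carbon. Compound 3 `CCC(NC(=O)C(CC(C)C)NC(=O)OCc1ccccc1)C(=O)C(=O)O` is still unmeasured. It differs from compound 2 by hydroxy in place of octylamino on a carbonyl carbon in all, which is hydroxy in place of octylamino on a carbonyl carbon. Among the compounds with values here, no measured compound carries hydroxy there, but the one measured exchange at this carbon stayed within the scatter, so no step beyond the scatter is expected. The expected step is a 1.3-fold higher number from compound 2 to compound 3 (0.10 log units; within the scatter) on this estimate. The estimate for compound 3 is 250000 nM (expected range 100000 nM to 600000 nM).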

Compound 3, half-maximal inhibitory concentration: 100000 nM
The estimate for compound 3 lay 2.5-fold (0.40 log units) above the measured number; the measured number falls inside the stated range.
By their numbers in this assay, from the lowest: compounds 3, 2 and 1 (each within the scatter of the next, the first and the last beyond it).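

Going by these compounds alone, replacing the methyl on the ester oxygen with hydrogen, which turns the ester into the free acid, gives the only step at this end of the molecule that clears the usual scatter, and only modestly (a 2.8-fold lower number from compound 1 to compound 3 (0.45 log units; beyond the scatter)). The acid and the octylamino amide remain within the scatter of each other (a 2.0-fold lower number from compound 2 to compound 3 (0.30 log units; within the scatter)), so this position does not separate them. Nothing available explains the change in number.

From the compounds shown here alone, whether a butylamino group, a benzylamino group or an unsubstituted amide here would give a lower number stays open. So does whether any group at this carbonyl carbon can bring the number far below those of these three compounds.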